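Side-chain ester on compound 1: expected cytotoxicity

The source may hold more compounds than are shown below. What is called first, only, known or untested is meant among the compounds shown, and "the series" means these compounds.

Two compounds have numbers in a functional assay on HeLa cells (Homo sapiens) for cytotoxicity, read by MTT assay, with a stated time of 48 h; a lower number here means a stronger inhibitor, a higher number a weaker inhibitor. Compound 1 `COc1ccc(O)c2c1C(=O)C=C(CCC=C(C)C)C2=O` gives 910 nM there, and compound 2 `COc1ccc(O)c2c1C(=O)C(CCC=C(C)C)=CC2=O` gives 6380 nM. Compound 1 therefore holds the lowest number of the two, and its gap to compound 2 is stated to be beyond the usual scatter; beyond that, the pair shows only these two values.

The next compound is compound 3 `COc1ccc(O)c2c1C(=O)C=C([C@H](CC=C(C)C)OC(=O)C=C(C)C)C2=O`, to be measured in this assay. It differs from compound 1 in one place: ((2-methylprop-1-en-1-yl)carbonyl)oxy in place of hydrogen on a saturated chain carbon bound to a double-bonded ring carbon and a saturated chain carbon. Within the data shown here, no step between measured compounds is available for this kind of change, so nothing measured so far tells in which direction or by how much the read-out should move.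

The working expectation for compound 3 is a step of a 1.3-fold lower number from compound 1 to compound 3 (0.11 log units; within the scatter) from compound 1, that is a small move toward a lower number, within or only just beyond the scatter. On that basis compound 3 is estimated at 700 nM, with a range from 250 nM to 2500 nM.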

Compound 3, half-maximal inhibitory concentration: 820 nM
Compound 3: the middle estimate sits 1.2-fold (0.07 log units) below what was measured, within the range that was stated.
By their numbers in this assay, from the lowest: compounds 3 and 1 (each within the scatter of the next); then compound 2.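

In this assay, among these compounds, the step for this change reads a 1.1-fold lower number from compound 1 to compound 3 (0.05 log units; within the scatter) and so gives the first information on this position: the saturated chain carbon bound to a double-bonded ring carbon and a saturated chain carbon accepts ((2-methylprop-1-en-1-yl)carbonyl)oxy in place of hydrogen with no shift in the read-out beyond the scatter. Compounds 1 and 2 could not show this, since neither carries a group other than hydrogen at this carbon, whereas the entering group in compound 3 has 7 heavy atoms and no ring. Nothing at hand accounts for the near-identical read-outs, and no measurement bears on this result.

Still open, going by these compounds, is whether this carbon accepts other replacements equally well, such as a free hydroxyl, an amine or a simple acetyl ester, and whether the opposite configuration at this carbon gives a similar number. Also open, on these data alone, is whether the same ester, placed on the corresponding chain carbon of compound 2, would leave that compound's read-out similarly unchanged.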